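The source may report more compounds than this note shows. Statements on the series, on what has been measured and on what is new or still open speak of the compounds shown alone.

Measured set in a functional assay on MDA-MB-231 cells (Homo sapiens) for inhibition, read by sulforhodamine B assay; on this read-out lower numbers stand for stronger inhibition and higher numbers for weaker inhibition:
- compound 1 `COC(=O)CC/C(C)=C/Cc1c(OC)c(C)c2c(c1OCC#CCN1CCN(c3ccc(C#N)cc3)CC1)C(=O)OC2` gives > 50000 nM, a limit of the assay and not a number.
- compound 2 `COC(=O)CC/C(C)=C/Cc1c(OC)c(C)c2c(c1OCC#CCN1CCC(C(=O)OC)CC1)C(=O)OC2` gives > 50000 nM, likewise a limit.
- compound 3 `COC(=O)CC/C(C)=C/Cc1c(OC)c(C)c2c(c1OCC#CCN1CCN(C(c3ccccc3)c3ccc(Cl)cc3)CC1)C(=O)OC2` gives > 50000 nM, also a limit.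

Compound 1 stands at the same limit as the other two: the limit of > 50000 nM in this assay, at which 3 of the 3 values shown sit. Going by the values given here, no order among the three can be read from this, and no step between them is known. Compound 4 `COC(=O)CC/C(C)=C/Cc1c(OC)c(C)c2c(c1OCC#CCN1CCN(c3ccccc3OC)CC1)C(=O)OC2` has not yet been measured in this assay. It differs from compound 1 by 2-methoxyphenyl in place of 4-cyanophenyl on an amine nitrogen in a ring. With every value sitting at the limit, the set shows no effect of the group on the amine nitrogen in the ring. The expected step that the limit leaves unreadable from compound 1 to compound 4 is none beyond the scatter. Compound 4 is estimated at 60000 nM, between 20000 nM and 200000 nM, most probably again only a limit.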

Compound 4, half-maximal inhibitory concentration: > 50000 nM
Compound 4 gave a limit, no number; the forecaster's own chance of this, stated with the estimate: 80%; the middle value lies beyond the limit too.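

No step can be read between compound 1 and compound 4 in this assay, as both values are limits and not numbers: the limit of > 50000 nM in this assay, at which 4 of the 4 values shown sit.

The compounds shown leave open whether any group on the amine nitrogen in the ring changes inhibition.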